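Chloro for fluoro in a urea series, rat aorta

This account rests on a few compounds, and the source may have more. Where it says the series, first, only, none or still open, it means among the compounds named here.

Compound 1 `COc1ccc(NC(=O)NC2CC(C)(C)Oc3ccc(F)cc32)cc1` gives 15500 nM in a functional assay (aorta) with Rattus norvegicus as the target; a higher number here means that more compound is needed for the effect, a lower number that less compound is needed. For compound 2 `COc1ccc(NC(=O)NC2CC(C)(C)Oc3ccc(Cl)cc32)cc1` this assay reports only a limit, > 30000 nM. For compound 3 `Cc1cccc(NC(=O)NC2CC(C)(C)Oc3ccc(F)cc32)c1` this assay likewise reports only a limit, > 30000 nM. Compound 2 differs from compound 1 by chloro in place of fluoro on an aromatic carbon, and that change made a step of an at least 1.9-fold higher number from compound 1 to compound 2 (0.28 log units; that floor lies within the scatter). Compound 3 differs from compound 1 by 3-methylphenyl in place of 4-methoxyphenyl on an amide-type nitrogen. Compound 4 `Cc1cccc(NC(=O)NC2CC(C)(C)Oc3ccc(Cl)cc32)c1` has not been measured; it differs from compound 3 by chloro in place of fluoro on an aromatic carbon, the same change as from compound 1 to compound 2. Compound 3 already stands at the limit of > 30000 nM in this assay, at which 2 of the 3 values shown sit, and the earlier step of an at least 1.9-fold higher number from compound 1 to compound 2 (0.28 log units; that floor lies within the scatter) ran toward higher numbers. Compound 4 is therefore expected to give 60000 nM, most likely reported again only as a limit. The step expected here is a step that the limit leaves unreadable from compound 3 to compound 4.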

Compound 4, half-maximal effective concentration: > 10000 nM
Compound 4: a limit, no number; the forecaster's own chance of this, stated with the estimate: 90%; the middle value lies beyond the limit too.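

In this assay compound 4 gives only a limit, > 10000 nM, so its steps from compound 3 and from compound 2 cannot be read. The compounds shown leave open how far chloro in place of fluoro moves the number when 3-methylphenyl is present.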